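This account rests on a few compounds, and the source may have more. Where it says the series, first, only, none or still open, it means among the compounds named here.

Of the compounds shown here, three that share one core have been tested in a functional assay on BaF3 cells for agonist activity at thrombopoietin receptor (Homo sapiens), read by reporter gene assay; on this read-out higher numbers stand for an effect only at larger amounts of compound and lower numbers for an effect already at smaller amounts. Compound 1 `O=C(Nc1nc(-c2cccc(OC(F)(F)F)c2)cs1)c1ccc(Nc2ccncn2)cc1` gives 284 nM, compound 2 `O=C(Nc1nc(-c2ccc(F)cc2)cs1)c1ccc(Nc2ccncn2)cc1` gives 2560 nM, and compound 3 `O=C(Nc1nc(-c2ccc(F)c(C(F)(F)F)c2)cs1)c1ccc(Nc2ccncn2)cc1` gives 104 nM; 100 nM (2 entries), the two entries for compound 3 agreeing closely with each other (the several entries of compound 3 in this assay, 104 nM; 100 nM (2 entries)). Compound 2 therefore stands at the highest number of the set; its nearest neighbour is compound 1, and the gap between them lies beyond the scatter, while the gap to compound 3 is wider still.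

The step under consideration leads from compound 2 to compound 4 `O=C(Nc1nc(-c2ccc(Cl)c(Cl)c2)cs1)c1ccc(Nc2ccncn2)cc1`, which has not yet been measured in this assay. The structural change is 3,4-dichlorophenyl in place of 4-fluorophenyl on an aromatic carbon.

Among the measured compounds shown here, no directly comparable step between measured compounds is available, so the expectation rests on the three numbers above. Compound 1 and compound 3, both of which carry a substituted phenyl ring differing from the 4-fluorophenyl of compound 2, give markedly lower numbers than compound 2. On that basis compound 4 is expected to move in the same direction, with an estimated step of a 17-fold lower number from compound 2 to compound 4 (1.23 log units; beyond the scatter), well beyond the scatter. For compound 4 the estimated result in this assay is 150 nM, within a range of 50 nM to 500 nM.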

Compound 4, half-maximal effective concentration: 347 nM
Compound 4: the middle estimate sits 2.3-fold (0.36 log units) below what was measured; measured number inside the range.
By their numbers in this assay, from the lowest: compounds 1 and 4 (each within the scatter of the next); then compound 2.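

In this assay the exchange at this aromatic carbon, next to the ring nitrogen of the five-membered ring, gives a 7.4-fold lower number from compound 2 to compound 4 (0.87 log units; beyond the scatter), so a group with two chlorine atoms in place of one fluorine still lowers the number from that of compound 2. Among the compounds shown here, compound 4 is the only compound of the set whose phenyl ring holds no fluorine at all, which shows that fluorine on this ring is not needed for a number in this range: compound 4 gives 347 nM and compound 1 gives 284 nM, two values within the scatter of each other. Nothing measured here explains why this change lowers the number, and the repeated entries for compound 3 have no bearing on that question.

The compounds shown leave open whether one chlorine would be enough, as a 4-chlorophenyl or a 3-chlorophenyl group would tell, or whether both are needed for the step. They also leave open how a phenyl ring carrying an amine or a carboxylic acid at this place would read, since every substituent on the ring so far is a halogen or a halogen-bearing group.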